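One Fluoro Added to Compound 3

The compounds below may be only part of what the source reports. "The series", "measured", "known", "first", "only" and "open" are said of these compounds alone.

Three small compounds have so far been tested in a functional assay on B16-F10 cells (Mus musculus) for antiproliferative activity, read by colorimetric assay and MTT assay, with a stated time of 48 h; a lower number here means a stronger inhibitor, a higher number a weaker inhibitor. Compound 1 (`O=C(NS(=O)(=O)c1ccccc1)c1cccnc1`) gives 14500 nM, compound 2 (`O=C(NS(=O)(=O)c1ccc(F)cc1)c1ccncc1`) gives 13800 nM, and compound 3 (`O=C(NS(=O)(=O)c1ccccc1)c1ccccn1`) gives 14200 nM. Compound 3 therefore stands level with the other two: all three numbers lie within the usual scatter of repeated measurements, so they cannot be ranked.

The next compound is compound 4 (`O=C(NS(=O)(=O)c1ccc(F)cc1)c1ccccn1`). It is compound 3 with a single change, fluoro in place of hydrogen on an aromatic carbon, para to a large group (fluoro in place of hydrogen on an aromatic carbon).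

Among the measured compounds shown here, only one measured step compares two compounds that differ in one place, a 1.0-fold lower number from compound 1 to compound 3 (0.01 log units; within the scatter). For the measured compounds named here, that step is within the scatter, but it concerns the group on the carbonyl, so no measured step isolates the fluoro. Compound 2 also carries a fluoro and gives 13800 nM, but its group on the carbonyl differs from that of compound 3, so it offers only indirect support. Nothing here points to a change beyond the scatter in this assay, in either direction. The expected change is small, an estimated 1.1-fold lower number from compound 3 to compound 4 (0.02 log units; within the scatter). For compound 4 the estimate is 13500 nM, with an expected range of 8500 nM to 20000 nM.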

Compound 4, half-maximal inhibitory concentration: 10900 nM
The estimate for compound 4 lay 1.2-fold (0.09 log units) above the measured number; the measured number falls inside the stated range.
By their numbers in this assay, from the lowest: compounds 4, 2, 3 and 1 (each within the scatter of the next).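

Among the compounds shown here, this is the first direct test of fluoro in place of hydrogen on an aromatic carbon, para to a large group. In this assay the change gives a 1.3-fold lower number from compound 3 to compound 4 (0.11 log units; within the scatter), so at this position the single fluoro does not move the number beyond what repeated measurements would scatter by. Swapping the group on the carbonyl while the fluoro stays in place gives a 1.3-fold lower number from compound 2 to compound 4 (0.10 log units; within the scatter), which shows that pyridin-2-yl and pyridin-4-yl cannot be told apart here even with the fluoro present, something the earlier step between compounds without fluoro could not show; no measurement offered here accounts for these numbers.

The compounds shown carry only hydrogen or fluoro at this position, so it remains open whether a larger or very different group there, such as a methoxy, an amine or a carboxylic acid, would move the number beyond the scatter. On these data alone, it also remains open whether any change to the shared core, rather than to these two small sites, would produce a clear difference in this assay.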